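The source may report more compounds than this note shows. Statements on the series, on what has been measured and on what is new or still open speak of the compounds shown alone.

Among the measured compounds shown here, compound 2 `Cc1ccc(NC2=CC(=O)c3c(nc4n3[C@H]3OC[C@@H](O)[C@H]3OC4)C2=O)cc1C` is the one member of this small set whose activity in a functional assay on ECa-109 cells for inhibition, with ECa-109 cell line (Homo sapiens) as the target, read by sulforhodamine B assay (a lower number here means a stronger inhibitor, a higher number a weaker inhibitor), is given as a number: in this assay compound 2 gives 4090 nM. Its nearest relative, compound 1 `CCc1ccc(NC2=CC(=O)c3c(nc4n3[C@H]3OC[C@@H](O)[C@H]3OC4)C2=O)cc1`, differs from it only in the group on the amine nitrogen. In this assay compound 1 gives > 4000 nM, which is a limit of the assay rather than a number. For the measured compounds named here, the step that the limit leaves unreadable from compound 1 to compound 2 therefore cannot be sized, and the limit of > 4000 nM in this assay, at which 1 of the 2 values shown sits, is the only context available for compound 2. Compound 3 `CCOc1ccccc1NC1=CC(=O)c2c(nc3n2[C@H]2OC[C@@H](O)[C@H]2OC3)C1=O` has not yet been measured; it carries 2-ethoxyphenyl in place of 3,4-dimethylphenyl on an amine nitrogen. Going by the values given here, no measured step covers this change, since the single step in this assay is hidden behind the limit. With compound 2 sitting close to that limit, compound 3 is expected to remain in the same weak region, and the step of a 1.2-fold higher number from compound 2 to compound 3 (0.09 log units; within the scatter) is expected to stay within the usual scatter. The estimate for compound 3 in this assay is therefore 5000 nM, in a range from 1500 nM to 15000 nM, with a real chance that only a limit is reported.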

Compound 3, half-maximal inhibitory concentration: 4320 nM
Estimate against measurement, compound 3: 1.2-fold (0.06 log units) above; measured number inside the range.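

In this assay, the amine nitrogen now has a step that can be read: a 1.1-fold higher number from compound 2 to compound 3 (0.02 log units; within the scatter). The entering 2-ethoxyphenyl carries oxygen and 3,4-dimethylphenyl does not, and it is also the larger group by heavy atoms, yet this exchange leaves compound 2 and compound 3 level with each other within the scatter. Compound 1 stays a limit of the assay and not a number, so the steps that start from it cannot be read: the limit of > 4000 nM in this assay, at which 1 of the 3 values shown sits.

The compounds shown all carry a phenyl ring with small alkyl or alkoxy groups on the amine nitrogen, so they leave open whether a pyridine ring in its place, or an amine or a carboxylic acid on the phenyl ring, would move the number beyond the scatter. They also leave open whether any change to the shared core, rather than to the group on the amine nitrogen, would bring a clearly stronger inhibitor in this assay.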